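The source may report more compounds than this note shows. Statements on the series, on what has been measured and on what is new or still open speak of the compounds shown alone.

Of the compounds shown here, three have so far been measured in a functional assay on CCRF-CEM cells (Homo sapiens) for inhibition, read by MTT assay, with a stated time of 4 days; a lower number here means a stronger inhibitor, a higher number a weaker inhibitor. Compound 1 `O=C1NCCN1C(c1ccccc1)(c1ccccc1)c1ccccc1` gives 27000 nM, compound 3 `COc1cc(NC(C)CCCNC(=O)NNC(=O)N(C)C(c2ccccc2)c2ccccc2)c2ncccc2c1` gives 10000 nM, and compound 2 `COc1cc(NC(C)CCCNC(=O)Nc2ccc(Cl)c(C(F)(F)F)c2)c2ncccc2c1` gives 3100 nM. Compound 2 therefore has the lowest number of the three, and its gaps to compound 3 and to compound 1 both lie beyond the usual scatter, so it is the strongest inhibitor among them. Compound 4 `COc1cc(NC(C)CCCNC(=O)NNC(=O)NCCCO)c2ncccc2c1` has not yet been measured. It differs from compound 2 in one place (((3-hydroxypropyl)carbamoyl)amino in place of 4-chloro-3-(trifluoromethyl)phenyl on an amide-type nitrogen). Compound 3, which also lacks the 4-chloro-3-(trifluoromethyl)phenyl, sits well above compound 2, so a weakening move beyond the scatter is expected. The step of a 6.5-fold higher number from compound 2 to compound 4 (0.81 log units; beyond the scatter) is the estimated size of that move. Compound 4 is expected at 20000 nM, with a likely range from 5000 nM to 80000 nM.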

Compound 4, half-maximal inhibitory concentration: > 250000 nM
Compound 4 was reported as a limit; the forecaster's own chance of this, stated with the estimate: 20%; middle value at least 12-fold (1.09 log units) from the limit.
By their numbers in this assay, from the lowest: compound 2; then compound 3; then compound 1. At a limit, above all of these: compound 4.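

Among the compounds shown here, this is the first direct reading of this position, since no earlier pair of measured compounds differed in one place only. In this assay, going by these compounds, putting ((3-hydroxypropyl)carbamoyl)amino in place of 4-chloro-3-(trifluoromethyl)phenyl on an amide-type nitrogen gives an at least 80-fold higher number from compound 2 to compound 4 (1.90 log units; beyond the scatter), a large weakening whose true size remains unknown. Compound 4 is reported as a limit, not a number: the limit of > 250000 nM in this assay, at which 1 of the 4 values shown sits.

The compounds shown do not separate the loss of the ring from the entry of the new chain. A plain phenyl or an unsubstituted butyl chain on that nitrogen would help tell these apart.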